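From 3-chlorophenyl to 1-methyl-1H-pyrazol-4-yl

The compounds below may be only part of what the source reports. "The series", "measured", "known", "first", "only" and "open" are said of these compounds alone.

Measured in a functional assay on MCF7 cells (Homo sapiens) for antiproliferative activity, read by MTT assay, with a stated time of 72 h; a lower number here means a stronger inhibitor, a higher number a weaker inhibitor:
Compound 1 `O=C(Nc1ccc(Nc2nccc(NC3CC3)n2)cc1)Nc1ccc(Cl)c(C(F)(F)F)c1`: 38300 nM
Compound 2 `O=C(Nc1ccc(Nc2nccc(Nc3ccccc3)n2)cc1)Nc1ccc(Cl)c(C(F)(F)F)c1`: > 50000 nM (a limit, not a number)
Compound 3 `O=C(Nc1ccc(Nc2nccc(Nc3cccc(Cl)c3)n2)cc1)Nc1ccc(Cl)c(C(F)(F)F)c1`: 10400 nM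

Compound 3 has the lower of the two actual numbers, and compound 2 is reported only as a limit. Compound 4 `Cn1cc(Nc2ccnc(Nc3ccc(NC(=O)Nc4ccc(Cl)c(C(F)(F)F)c4)cc3)n2)cn1` carries 1-methyl-1H-pyrazol-4-yl in place of 3-chlorophenyl on a nitrogen on an aromatic ring. For the measured compounds named here, no measured step makes this exchange. The closest evidence is a 3.7-fold lower number from compound 1 to compound 3 (0.57 log units; beyond the scatter) and an at least 4.8-fold lower number from compound 2 to compound 3 (0.68 log units; beyond the scatter), while an at least 1.3-fold higher number from compound 1 to compound 2 (0.11 log units; that floor lies within the scatter). Both other groups therefore give higher numbers than 3-chlorophenyl, so a modest rise is expected in this assay. Compound 4 is estimated at 24000 nM, within 8000 nM to 50000 nM. The expected change is a 2.3-fold higher number from compound 3 to compound 4 (0.36 log units; beyond the scatter).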

Compound 4, half-maximal inhibitory concentration: 9770 nM
For compound 4 the middle estimate is 2.5-fold (0.39 log units) above the measured one, and the stated range covers the measured number.
By their numbers in this assay, from the lowest: compounds 4 and 3 (each within the scatter of the next); then compound 1. At a limit, above all of these: compound 2.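

With a 1.1-fold lower number from compound 3 to compound 4 (0.03 log units; within the scatter), 1-methyl-1H-pyrazol-4-yl does as well as 3-chlorophenyl on this nitrogen, so a ring without chlorine, and with two hydrogen-bond acceptors, also reaches this level. In place of cyclopropyl, the same group gives a 3.9-fold lower number from compound 1 to compound 4 (0.59 log units; beyond the scatter). In place of phenyl, whose value is only a limit, it gives an at least 5.1-fold lower number from compound 2 to compound 4 (0.70 log units; beyond the scatter).

From the compounds shown here alone, what remains open is whether the methyl on the new ring is needed at all. It is also unclear whether an amine or a carboxylic acid on that ring would shift the number in this assay.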